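The source may report more compounds than this note shows. Statements on the series, on what has been measured and on what is new or still open speak of the compounds shown alone.

Compound 1 `CC(C)COC(=O)N1CCN(C(=O)c2nc(Nc3cc(C4CC4)[nH]n3)c3cc(Cl)ccc3n2)C[C@H]1C`: in an assay for inhibition of serine/threonine-protein kinase PAK 4 (Homo sapiens), read by FRET and Z'-LYTE, with a stated time of 60 min, tested at 0.5 uM, in the presence of a further agent that is not named here (on this read-out lower numbers stand for a weaker effect and higher numbers for a stronger effect at the one concentration tested), compound 1 gives 0.8%.
Compound 2 `C[C@@H]1CN(C(=O)c2nc(Nc3cc(C4CC4)[nH]n3)c3cc(Cl)ccc3n2)CCN1C(=O)OC(C)(C)C`: in this assay compound 2 gives 0.1%.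
Compound 3 `CCCCCOC(=O)N1CCN(C(=O)c2nc(Nc3cc(C4CC4)[nH]n3)c3cc(Cl)ccc3n2)C[C@H]1C`: in this assay compound 3 gives -3.8%.

Compound 2 stands second highest of the three numbers. Its nearest neighbour is compound 1, with a number 0.7 percentage points lower from compound 1 to compound 2 (within the scatter); its furthest is compound 3, with a number 3.9 percentage points lower from compound 2 to compound 3 (within the scatter). Both steps lie within the scatter, so the three measured compounds cannot be told apart.

Compound 4 `COC(=O)N1CCN(C(=O)c2nc(Nc3cc(C4CC4)[nH]n3)c3cc(Cl)ccc3n2)C[C@H]1C` differs from compound 2 by methyl in place of tert-butyl on an oxygen next to a carbonyl group. For the measured compounds named here, the steps that bear on this change are those that already altered the group on that oxygen, a number 0.7 percentage points lower from compound 1 to compound 2 (within the scatter) and a number 3.9 percentage points lower from compound 2 to compound 3 (within the scatter), neither of them beyond the scatter. For compound 4 the expected step is a number 0.1 percentage points lower from compound 2 to compound 4 (within the scatter), again not beyond the scatter. The estimate for compound 4 is 0%, between -8% and 8%.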

Compound 4, a percentage reported as inhibition, at one concentration (the size of the read-out at that concentration, not a potency): 73.9%
Compound 4: middle estimate off by 73.9 percentage points, on the low side; measured number above the stated range.
By their numbers in this assay, from the lowest: compounds 3, 2 and 1 (each within the scatter of the next); then compound 4.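

In this assay, the group on an oxygen next to a carbonyl group proves decisive: methyl in place of tert-butyl gives a number 73.8 percentage points higher from compound 2 to compound 4 (beyond the scatter), and the other two steps are of like size, a number 73.1 percentage points higher from compound 1 to compound 4 (beyond the scatter) and a number 77.7 percentage points higher from compound 3 to compound 4 (beyond the scatter). The earlier compounds shown here, with isobutyl, tert-butyl and pentyl there, lay within the scatter of one another, so only compound 4, with methyl, stands apart. Nothing given here accounts for this jump. On these data alone, whether ethyl on that oxygen keeps the effect stays open, as does whether an amine nitrogen in place of that oxygen would.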